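The source may hold more compounds than are shown below. What is called first, only, known or untested is meant among the compounds shown, and "the series" means these compounds.

Compound 1, with the structure `CCN(CC)CN1C(=O)/C(=N\c2nc3ccc(C)cc3s2)c2c(Br)cccc21`, is one of three compounds whose growth-inhibiting effect has been measured. In a functional assay on MCF7 cells (Homo sapiens) for cytotoxicity, read by sulforhodamine B assay, with a stated time of 48 h (a lower number here means a stronger inhibitor of growth, a higher number a weaker inhibitor of growth), compound 1 gives 30200 nM. Compound 2, with the structure `O=C1C(=O)N(CN(c2ccccc2)c2ccccc2)c2cccc(Cl)c21`, and compound 3, with the structure `O=C1C(=O)N(CN(c2ccccc2)c2ccccc2)c2cccc(Br)c21`, share a core that differs from the core of compound 1; the difference between the two cores is not broken down here. In this assay compound 2 gives 29700 nM, and compound 3 gives 110000 nM. Between those two the only change is chloro in place of bromo on an aromatic carbon, and it brought a 3.7-fold lower number from compound 3 to compound 2 (0.57 log units; beyond the scatter).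

Compound 4, with the structure `CCN(CC)CN1C(=O)/C(=N\c2nc3ccc(C)cc3s2)c2c(Cl)cccc21`, has not been measured. It differs from compound 1 by chloro in place of bromo on an aromatic carbon, the same change seen between compound 3 and compound 2, at a place described in the same words.

Resting on the step of a 3.7-fold lower number from compound 3 to compound 2 (0.57 log units; beyond the scatter), the corresponding change is expected to give a 2.5-fold lower number from compound 1 to compound 4 (0.40 log units; beyond the scatter) in this assay. Compound 4 is therefore estimated at 12000 nM, with a likely range from 4000 nM to 35000 nM.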

Compound 4, concentration for 50% growth inhibition: 19200 nM
Compound 4: the middle estimate sits 1.6-fold (0.20 log units) below what was measured, and the stated range covers the measured number.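

On the core of compound 1, chloro in place of bromo gives a 1.6-fold lower number from compound 1 to compound 4 (0.20 log units; within the scatter) in this assay, so on this core the swap does not move the number beyond what repeated measurements would scatter by. Set beside the earlier step on the other core, the change does not behave measurably differently from one core to the other: the same change on two cores in this assay, a 3.7-fold lower number (0.57 log units; beyond the scatter) from compound 3 to compound 2 and a 1.6-fold lower number (0.20 log units; within the scatter) from compound 1 to compound 4, 2.4-fold (0.37 log units) apart, within the scatter of two such steps This shows that nothing here argues against carrying the change between these two cores, but it does not show that the effect is equal on both, or that chloro truly beats bromo on the core of compound 1, and a single pair on each core cannot establish a rule for the series.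

The compounds shown leave open what a fluoro group, a methyl group, a methoxy group or plain hydrogen would do on the same aromatic carbon. They also leave open whether the swap would hold on a core carrying a different amine on the ring nitrogen's side chain.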